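The source may report more compounds than this note shows. Statements on the series, on what has been measured and on what is new or still open speak of the compounds shown alone.

Compound 1 `C=CCO/N=C/c1c(N)ncnc1Oc1ccc2[nH]c(C)cc2c1F`: 40 nM
Compound 2 `COCCO/N=C/c1c(N)ncnc1Oc1ccc2[nH]c(C)cc2c1F`: 387 nM
Compound 3 `CCO/N=C/c1c(N)ncnc1Oc1ccc2[nH]c(C)cc2c1F`: not yet measured

In a functional assay on HCT-116 cells (Homo sapiens) for antiproliferative activity (on this read-out higher numbers stand for weaker inhibition and lower numbers for stronger inhibition), compound 2 has the higher of the two numbers, at 387 nM. The change to compound 3 is hydrogen in place of methoxy on a saturated chain carbon, two bonds along the chain from an oxygen on an unsaturated carbon. For the measured compounds named here, only one measured step bears on this: a 9.7-fold higher number from compound 1 to compound 2 (0.99 log units; beyond the scatter). Compound 3, like compound 1, carries no methoxy, so a somewhat smaller step towards a lower number is expected in this assay, though this rests on a single pair. The expected change is a 5.5-fold lower number from compound 2 to compound 3 (0.74 log units; beyond the scatter). Compound 3 is estimated at 70 nM, with an expected range of 25 nM to 200 nM.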

Compound 3, half-maximal inhibitory concentration: 36 nM
Compound 3: middle estimate off by 1.9-fold (0.29 log units), on the high side; low and high end bracket the measured number.
By their numbers in this assay, from the lowest: compounds 3 and 1 (each within the scatter of the next); then compound 2.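

In this assay, hydrogen in place of methoxy on this saturated chain carbon gives an 11-fold lower number from compound 2 to compound 3 (1.03 log units; beyond the scatter), so the higher number goes with the methoxy and not with the lack of a vinyl. Methyl in place of vinyl gives a 1.1-fold lower number from compound 1 to compound 3 (0.05 log units; within the scatter), so these two ends of the chain are not told apart in this read-out. No evidence on hand accounts for the effect of the methoxy.

Still open, from the compounds shown here alone, is whether a hydroxyl or an amine at this carbon would give the same higher number as methoxy. Also open, going by these compounds, is how a longer chain without any oxygen would read.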